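This account rests on a few compounds, and the source may have more. Where it says the series, first, only, none or still open, it means among the compounds named here.

Measured in a functional assay on SW48 cells (Homo sapiens) for antiproliferative activity, read by MTT assay, with a stated time of 72 h; a higher number here means a weaker inhibitor, a lower number a stronger inhibitor:
- Compound 1 `COc1ccc([C@H]2[C@H](NC(=O)c3ccc(F)cc3)C(=O)N2c2cc(OC)c(OC)c(OC)c2)cc1O`: 384 nM
- Compound 2 `COc1ccc(C(=O)N[C@@H]2C(=O)N(c3cc(OC)c(OC)c(OC)c3)[C@H]2c2ccc(OC)c(O)c2)cc1`: 108 nM
- Compound 3 `COc1ccc([C@H]2[C@H](NC(=O)c3ccc4ccccc4c3)C(=O)N2c2cc(OC)c(OC)c(OC)c2)cc1O`: 220 nM

Compound 2 has the lowest of the three numbers in this assay. Compound 4 `COc1ccc([C@H]2[C@H](NC(=O)C3CCCCC3)C(=O)N2c2cc(OC)c(OC)c(OC)c2)cc1O`, not yet measured, carries cyclohexyl in place of 4-methoxyphenyl on a carbonyl carbon.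

All three measured steps change the group on that carbonyl carbon. Methoxy in place of fluoro gave a 3.6-fold lower number from compound 1 to compound 2 (0.55 log units; beyond the scatter). Naphthalen-2-yl in place of 4-methoxyphenyl, the one step that starts from compound 2, gave a 2.0-fold higher number from compound 2 to compound 3 (0.31 log units; beyond the scatter). Naphthalen-2-yl in place of 4-fluorophenyl gave a 1.7-fold lower number from compound 1 to compound 3 (0.24 log units; within the scatter), which stays within the scatter. For the measured compounds named here, no compound with a non-aromatic ring at this place has been measured, so the precedent is thin.

A modest rise in the number is expected in this assay, similar in size to the two steps away from compound 2. The estimated change is a 3.2-fold higher number from compound 2 to compound 4 (0.51 log units; beyond the scatter). For compound 4 the expected value is 350 nM, with an estimated range of 120 nM to 1200 nM.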

Compound 4, half-maximal inhibitory concentration: 244 nM
Beside the measured number, compound 4's estimate is 1.4-fold (0.16 log units) above it; the measured number falls inside the stated range.
By their numbers in this assay, from the lowest: compound 2; then compounds 3, 4 and 1 (each within the scatter of the next).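

In this assay a non-aromatic ring on the carbonyl carbon proves compatible with a number in the range of the aromatic groups: a 1.1-fold higher number from compound 3 to compound 4 (0.04 log units; within the scatter) and a 1.6-fold lower number from compound 1 to compound 4 (0.20 log units; within the scatter) both lie within the scatter, so cyclohexyl cannot be told apart from naphthalen-2-yl or 4-fluorophenyl here. Only 4-methoxyphenyl stands apart, with a 2.3-fold higher number from compound 2 to compound 4 (0.35 log units; beyond the scatter) beyond the scatter, and since compounds 1 and 3 also carry aromatic rings, an aromatic ring alone does not mark out compound 2. No measurement in hand explains this gap.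

The compounds shown leave open whether the oxygen of 4-methoxyphenyl or the ring carrying it accounts for the lower number of compound 2. They also leave open how an open alkyl chain, an amine or a carboxylic acid on that carbonyl carbon would compare.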